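Trimethoxyphenyl in Place of Phenyl on the Five-Membered Ring

The source may hold more compounds than are shown below. What is called first, only, known or untested is meant among the compounds shown, and "the series" means these compounds.

Compound 1, `O=C(/C=C/c1cccc(O)c1)c1cccc(-n2cc(-c3ccc(Cl)cc3)[nH]c2=O)c1`, gives 1570 nM in a functional assay on LOX IMVI cells (Homo sapiens) for inhibition; a lower number here means a stronger inhibitor of growth, a higher number a weaker inhibitor of growth.
Compound 2, `COc1cc(/C=C/C(=O)c2cccc(-n3cc(-c4ccccc4)[nH]c3=O)c2)cc(OC)c1OC`, gives 480 nM in this assay.

Of the two numbers, compound 2 has the lower one, and the gap to compound 1 lies beyond the usual scatter. Compound 3, `COc1cc(/C=C/C(=O)c2cccc(-n3cc(-c4cc(OC)c(OC)c(OC)c4)[nH]c3=O)c2)cc(OC)c1OC`, is not yet measured. It differs from compound 2 by 3,4,5-trimethoxyphenyl in place of phenyl on an aromatic carbon. For the measured compounds named here, no measured pair shows this change, so its size is not known from the data. The step of a 1.4-fold higher number from compound 2 to compound 3 (0.13 log units; within the scatter) is expected to be small, possibly none beyond the scatter, with a slight lean toward a higher number. Compound 3 is expected to give 650 nM, within a range from 220 nM to 2000 nM.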

Compound 3, concentration for 50% growth inhibition: 1230 nM
For compound 3 the middle estimate is 1.9-fold (0.28 log units) below the measured one, within the range that was stated.
By their numbers in this assay, from the lowest: compound 2; then compounds 3 and 1 (each within the scatter of the next).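

In this assay, for the compounds shown here, the first pair that isolates this change shows that the aromatic carbon of the five-membered ring is sensitive to what it carries: 3,4,5-trimethoxyphenyl in place of phenyl gives a 2.6-fold higher number from compound 2 to compound 3 (0.41 log units; beyond the scatter) and so weakens growth inhibition. The step is modest, but it shows that this larger substituent is not favoured over plain phenyl here. Nothing available explains the loss.

Open, on these data alone, is how a phenyl ring bearing an amine or a carboxylic acid would compare at this position. Also open, as far as these compounds go, is whether one pair reflects a wider trend.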